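Changing the pendant phenyl ring: cytotoxicity outlook for compound 4

The compounds below may be only part of what the source reports. "The series", "measured", "known", "first", "only" and "open" are said of these compounds alone.

Compound 3 `Cc1cc(S(N)(=O)=O)ccc1NC(=O)COc1ccc(Cl)cc1C(O)c1cc(Cl)ccc1Cl` gives 36200 nM in an ADME assay on C8166 cells (Homo sapiens) for cytotoxicity, read by MTT assay; a lower number here means that less compound is tolerated, a higher number that more compound is tolerated. Its number sits with those of compound 1 `Cc1cc(S(N)(=O)=O)ccc1NC(=O)COc1ccc(Cl)cc1C(O)c1ccccc1C`, which gives 33900 nM, and compound 2 `Cc1ccc(C(O)c2cc(Cl)ccc2OCC(=O)Nc2ccc(S(N)(=O)=O)cc2C)c(C)c1`, which gives 26400 nM; all three lie within the scatter of one another. Compound 4 `Cc1cc(S(N)(=O)=O)ccc1NC(=O)COc1ccc(Cl)cc1C(O)c1cc(Cl)cc(C#N)c1` differs from compound 3 in one place: 3-chloro-5-cyanophenyl in place of 2,5-dichlorophenyl on a saturated chain carbon bound to an aromatic carbon and an oxygen on a saturated carbon. Going by the values given here, two measured steps touch the same place, namely a 1.1-fold higher number from compound 1 to compound 3 (0.03 log units; within the scatter) and a 1.4-fold higher number from compound 2 to compound 3 (0.14 log units; within the scatter), and neither moved the numbers beyond the scatter. The step of a 1.3-fold lower number from compound 1 to compound 2 (0.11 log units; within the scatter) was likewise flat. Therefore the expected step of a 1.1-fold lower number from compound 3 to compound 4 (0.03 log units; within the scatter) is none beyond the scatter. Compound 4 is estimated at 34000 nM, with a range from 20000 nM to 55000 nM.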

Compound 4, half-maximal cytotoxic concentration: 31600 nM
Beside the measured number, compound 4's estimate is 1.1-fold (0.03 log units) above it; the measured number falls inside the stated range.
By their numbers in this assay, from the lowest: compounds 2, 4, 1 and 3 (each within the scatter of the next).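

Going by these compounds alone, the nitrile is the first group at this position that brings a hydrogen-bond acceptor, yet in this assay the number stays flat against all three earlier compounds (a 1.1-fold lower number from compound 3 to compound 4 (0.06 log units; within the scatter)) (a 1.2-fold higher number from compound 2 to compound 4 (0.08 log units; within the scatter)) (a 1.1-fold lower number from compound 1 to compound 4 (0.03 log units; within the scatter)). Across these four compounds, then, methyl, chlorine and nitrile substituents on this ring give no step beyond the scatter. Nothing available explains why this position is so insensitive.

Still open, as far as these compounds go, is whether a ring bearing an amine or a carboxylic acid, or a longer chain in place of the ring, would also leave the number unchanged.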